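Swapping the ring on the core nitrogen

The source may report more compounds than this note shows. Statements on the series, on what has been measured and on what is new or still open speak of the compounds shown alone.

Within the data shown here, compound 2 `CN1CCN(c2ccc(Nc3ncc4nc(Nc5ccc(F)cc5)n([C@@H]5CCN(S(=O)(=O)C6CC6)C5)c4n3)cc2)CC1` gives 2.5 nM in a functional assay on HCC827 cells (Homo sapiens) for antiproliferative activity, read by MTT assay, with a stated time of 72 h (a higher number here means a weaker inhibitor, a lower number a stronger inhibitor), the lower of the two numbers measured so far; compound 1 `CN1CCN(c2ccc(Nc3ncc4nc(Nc5ccc(F)cc5)n([C@@H]5CCCN(C(=O)CO)C5)c4n3)cc2)CC1` gives 66 nM. Compound 3 `CN1CCN(c2ccc(Nc3ncc4nc(Nc5ccc(F)cc5)n(-c5cccc(NC(=O)CO)c5)c4n3)cc2)CC1` differs from compound 2 in one place: 3-(((hydroxymethyl)carbonyl)amino)phenyl in place of 1-(cyclopropylsulfonyl)pyrrolidin-3-yl on an aromatic nitrogen. Among the measured compounds shown here, the only measured step that bears on this is a 26-fold lower number from compound 1 to compound 2 (1.42 log units; beyond the scatter), where a (hydroxymethyl)carbonyl group on a saturated ring gave way to the cyclopropylsulfonyl pyrrolidine. Since compound 3 brings a (hydroxymethyl)carbonyl group back, an upward step is expected, an 8.0-fold higher number from compound 2 to compound 3 (0.90 log units; beyond the scatter), though smaller than that earlier step, landing between the two measured compounds. Compound 3 is estimated at 20 nM, in the range 5 nM to 80 nM.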

Compound 3, half-maximal inhibitory concentration: 7.5 nM
The estimate for compound 3 lay 2.7-fold (0.43 log units) above the measured number; measured number inside the range.
By their numbers in this assay, from the lowest: compound 2; then compound 3; then compound 1.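

In this assay, compound 1 and compound 3 both carry a (hydroxymethyl)carbonyl group, yet there is an 8.8-fold lower number from compound 1 to compound 3 (0.94 log units; beyond the scatter) when the piperidin-3-yl form gives way to the phenyl form, so this group alone does not fix the number at this position. Replacing the 1-(cyclopropylsulfonyl)pyrrolidin-3-yl group gives a 3.0-fold higher number from compound 2 to compound 3 (0.48 log units; beyond the scatter) and shows that a six-membered aromatic ring on this nitrogen can still give a low number. No measurement shown explains either step. Going by these compounds, it remains open how the ring and its attached group each contribute; a phenyl ring bearing a cyclopropylsulfonylamino group would help separate them.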